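The source may hold more compounds than are shown below. What is called first, only, known or untested is meant among the compounds shown, and "the series" means these compounds.

Measured compounds in an ADME assay on Huh-7 cells (Homo sapiens) for cytotoxicity; on this read-out lower numbers stand for higher toxicity in this test and higher numbers for lower toxicity in this test:

- compound 1, `Cc1ccccc1-c1nn(-c2ccc(Cl)cc2)cc1CNCCN1CCN(C)CC1`: compound 1 gives 17000 nM
- compound 2, `Cc1ccc(-n2cc(CNCCN3CCN(C)CC3)c(-c3ccccc3C)n2)c(C)c1`: for compound 2 the assay reports only a limit, > 20000 nM
- compound 3, `CSc1ccc(-n2cc(CNCCN3CCN(C)CC3)c(-c3ccccc3C)n2)cc1`: compound 3 gives 17000 nM

Compound 3 sits level with compound 1 at the digits shown, the step of no change at the digits printed from compound 1 to compound 3 (within the scatter) lying within the scatter. Against compound 2 only a floor can be stated, since compound 2 carries a limit (the limit of > 20000 nM in this assay, at which 1 of the 3 values shown sits); the step of an at least 1.1-fold lower number from compound 2 to compound 3 (0.07 log units; that floor lies within the scatter) is therefore a floor that itself lies within the scatter.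

Compound 4, `Cc1ccccc1-c1nn(Cc2ccccc2)cc1CNCCN1CCN(C)CC1`, is not yet measured in this assay. It differs from compound 3 by benzyl in place of 4-(methylsulfanyl)phenyl on an aromatic nitrogen. The three measured steps all change the group on that same aromatic nitrogen: an at least 1.1-fold higher number from compound 1 to compound 2 (0.07 log units; that floor lies within the scatter), no change at the digits printed from compound 1 to compound 3 (within the scatter) and an at least 1.1-fold lower number from compound 2 to compound 3 (0.07 log units; that floor lies within the scatter). None of them moves the read-out beyond the scatter, and one of them rests on a limit. On this evidence a benzyl group in that position is expected to leave the read-out where compound 3 stands, with the step of no change at the digits printed from compound 3 to compound 4 (within the scatter) expected to stay within the scatter. Compound 4 is therefore estimated at 17000 nM, in the range 8000 nM to 36000 nM, with a real chance that the assay again returns only a limit.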

Compound 4, half-maximal cytotoxic concentration: > 20000 nM
Compound 4 was reported as a limit; the forecaster's own chance of this, stated with the estimate: 30%; middle value at least 1.1-fold (0.07 log units) away from the limit.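

In this assay compound 4 is reported only as a limit, > 20000 nM. This extends the picture at the aromatic nitrogen from directly attached substituted phenyl rings to a benzyl group, and even this change of linkage, rather than of ring substituent alone, gives no step beyond the scatter: an at least 1.1-fold higher number from compound 3 to compound 4 (0.07 log units; that floor lies within the scatter), and an at least 1.1-fold higher number from compound 1 to compound 4 (0.07 log units; that floor lies within the scatter). The step between compound 2 and compound 4 cannot be read, and the set now offers less resolution at the top of the range: the limit of > 20000 nM in this assay, at which 2 of the 4 values shown sit.

The compounds shown leave open whether a longer chain between that nitrogen and the ring, or an amine or a carboxylic acid on the benzyl ring, would move the read-out beyond the scatter, and how far the true values of compound 2 and compound 4 lie from their limits. Going by these compounds, the 2-methylphenyl group and the large group on the ring stay the same throughout, so what changes there would do also remains open.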